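A few compounds are considered here, and "the series" means these few. Any claim that something is new, unique, unknown or untested is made for them only; others in the source may bear on it.

Measured so far:
compound 1 `COc1ccc(COCC(Cn2ccnc2)OCc2ccc(OC)cc2)cc1` – 9900 nM
compound 2 `COC(=O)c1ccc(COC(COCc2ccc(OC)cc2)Cn2ccnc2)cc1` – 1260 nM

In a functional assay for inhibition of Thromboxane-A synthase (Homo sapiens) (on this read-out higher numbers stand for weaker inhibition and lower numbers for stronger inhibition), compound 1 gives 9900 nM and compound 2 gives 1260 nM. Among the measured compounds shown here, compound 2 thus holds the lower of the two numbers, and compound 1 is its only neighbour; the single measured step, a 7.9-fold lower number from compound 1 to compound 2 (0.90 log units; beyond the scatter), separates them.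

Compound 3 `COc1ccc(COCC(Cn2ccnc2)OCc2ccc3c(c2)COC3=O)cc1` has not yet been measured. Relative to compound 2 the change is a group of 10 heavy atoms (8 carbon, 2 oxygen; one five-membered non-aromatic ring with 1 hetero atom, one six-membered aromatic ring of carbon only) in place of a group of 10 heavy atoms (8 carbon, 2 oxygen; one six-membered aromatic ring of carbon only), on a saturated chain carbon bound to an oxygen on a saturated carbon. For the measured compounds named here, the one measured step bears on this only in part: a 7.9-fold lower number from compound 1 to compound 2 (0.90 log units; beyond the scatter) placed a methoxycarbonyl on an aromatic carbon at the same end of the molecule, and compound 3 keeps the same count of oxygen and the same single double bond outside aromatic rings, but now closed into a five-membered non-aromatic ring fused to the aromatic ring. Going by the values given here, no measured step shows what such a ring closure does in this assay. The expectation is therefore a step of modest size at most, with no firm direction.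

For compound 3 the estimate in this assay is 1600 nM, within a range from 500 nM to 5000 nM. That estimate corresponds to an expected step of a 1.3-fold higher number from compound 2 to compound 3 (0.10 log units; within the scatter).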

Compound 3, half-maximal inhibitory concentration: 6200 nM
Beside the measured number, compound 3's estimate is 3.9-fold (0.59 log units) below it, and the stated range ends below it.
By their numbers in this assay, from the lowest: compound 2; then compounds 3 and 1 (each within the scatter of the next).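

In this assay the 4-(methoxycarbonyl)phenyl group and the group that enters have the same heavy-atom count and the same hydrogen-bond acceptor count, yet they are not interchangeable on this saturated chain carbon bound to an oxygen on a saturated carbon: the change gives a 4.9-fold higher number from compound 2 to compound 3 (0.69 log units; beyond the scatter) and removes most of the gain seen with the methoxycarbonyl. The comparison with the methoxy-bearing group gives a 1.6-fold lower number from compound 1 to compound 3 (0.20 log units; within the scatter), so compound 3 cannot be separated from compound 1 and the fused five-membered non-aromatic ring shows no measurable gain over it. Nothing measured on these compounds accounts for the difference between the open and the closed group.

From the compounds shown here alone, it remains open whether a carboxylic acid, a primary amide or an ethyl ester in place of the methoxycarbonyl would keep or extend the number of compound 2, and whether a six-membered non-aromatic ring closure would behave like the five-membered one. The shared core stays unchanged in all three compounds, so the effect of any change there on these numbers is also unknown.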